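This account rests on a few compounds, and the source may have more. Where it says the series, first, only, none or still open, it means among the compounds named here.

Three related compounds have been tested so far. In a functional assay on MCF7 cells (Homo sapiens) for antiproliferative activity (a higher number here means a weaker inhibitor of growth, a lower number a stronger inhibitor of growth), compound 1 (`Oc1ccc(-c2nc3ccccc3s2)cc1O`) gives 2190 nM as its concentration for half-maximal growth inhibition, compound 2 (`COc1ccc(-c2nc3ccccc3s2)cc1OC`) gives 52700 nM and compound 3 (`COc1ccc(-c2nc3cc(F)ccc3s2)cc1`) gives 490 nM on the same read-out. Compound 3 therefore holds the lowest number of the three, and its distance from each of the others lies beyond the scatter.

Compound 4 (`COc1ccc(-c2nc3cc(F)ccc3s2)cc1F`) differs from compound 3 in one place (fluoro in place of hydrogen on an aromatic carbon): the new fluoro sits ortho to a methoxy group and meta to a large group. Going by the values given here, no two measured compounds differ in only one place, so the data offer no direct precedent for this change. An estimated step of a 1.2-fold lower number from compound 3 to compound 4 (0.09 log units; within the scatter) is expected, which would not go beyond the scatter. The gap between compound 1 at 2190 nM and compound 2 at 52700 nM shows how far these values can spread, so the range is kept broad. Compound 4 is estimated at 400 nM with an expected range from 80 nM to 2500 nM in this assay once it is measured.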

Compound 4, concentration for 50% growth inhibition: 870 nM
Estimate against measurement, compound 4: 2.2-fold (0.34 log units) below, and the stated range covers the measured number.
By their numbers in this assay, from the lowest: compounds 3 and 4 (each within the scatter of the next); then compound 1; then compound 2.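

In this assay, going by these compounds alone, this is the first comparison between two compounds that differ in one place, and it gives a 1.8-fold higher number from compound 3 to compound 4 (0.25 log units; within the scatter) for fluoro in place of hydrogen on an aromatic carbon. Compound 3 and compound 4 cannot be told apart on this read-out, so a fluoro ortho to a methoxy group and meta to a large group is accommodated here, and both compounds stay ahead of compound 1 and compound 2 in the ranking. This holds for this one position and this one pair only.

As far as these compounds go, whether a chlorine, a methyl group or an amine at the same position would stay as close to compound 3 remains open, as does the result of placing fluoro elsewhere on this ring. No measurement available here explains why this change gives the result it does.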